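Ethyl on the Distal Ring of a Biphenyl Anilide

This account rests on a few compounds, and the source may have more. Where it says the series, first, only, none or still open, it means among the compounds named here.

Of the compounds shown here, three built on one shared core have been measured in a functional assay on MIA PaCa-2 cells (Homo sapiens) for cytotoxicity, read by MTT assay, with a stated time of 72 h; on this read-out lower numbers stand for stronger inhibition and higher numbers for weaker inhibition. Compound 1 `COc1cc(NC2=CC(=O)c3ncncc3C2=O)cc(OC)c1` gives 7700 nM. Compound 2 `O=C1C(Nc2ccc(-c3ccccc3)cc2)=CC(=O)c2ncncc21` gives 900 nM, the lower of the two numbers, with the gap to compound 1 lying beyond the scatter. Compound 3 `O=C1C(Nc2cccc(B(O)O)c2)=CC(=O)c2ncncc21` reaches only a limit of the assay, reported as > 10000 nM.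

Compound 4 `CCc1ccc(-c2ccc(NC3=CC(=O)c4ncncc4C3=O)cc2)cc1` is compound 2 carrying (ethyl in place of hydrogen on an aromatic carbon). For the measured compounds named here, no measured pair mirrors this change, so the size of the step is open; the expected step is a 1.3-fold lower number from compound 2 to compound 4 (0.11 log units; within the scatter), small and downward or none beyond the scatter, since the biphenyl anilide of compound 2 already gives 900 nM. Compound 4 is therefore estimated at 700 nM, with a range from 250 nM to 2500 nM.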

Compound 4, half-maximal inhibitory concentration: 2000 nM
Estimate against measurement, compound 4: 2.9-fold (0.46 log units) below, within the range that was stated.
By their numbers in this assay, from the lowest: compound 2; then compound 4; then compound 1. At a limit, above all of these: compound 3.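

In this assay the change from phenyl to 4-ethylphenyl brings a 2.2-fold higher number from compound 2 to compound 4 (0.35 log units; beyond the scatter) and so shows that this aromatic carbon, para to a large group, gains nothing from ethyl in place of hydrogen. For the compounds shown here, this is the first measured step at this position, and it is a modest one. Nothing shown gives a cause for this step.
From the compounds shown here alone, whether methyl, fluorine, a longer chain, an amine or a carboxylic acid on this carbon would raise or lower the number stays open. So does whether ethyl would have the same effect on another carbon of this ring.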